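The source may hold more compounds than are shown below. What is called first, only, known or untested is meant among the compounds shown, and "the series" means these compounds.

Going by the values given here, in a functional assay on SH-SY5Y cells (Homo sapiens) for antagonist activity, read by cAMP accumulation (a higher number here means a more potent compound, by a factor of ten per unit of this negative logarithm, a lower number a less potent compound), compound 3 `OCCOc1ccc(Cc2ccc(NC3=NCCN3)cc2)cc1` gives 8, the lowest of the three numbers so far. Compound 1 `CCCOc1ccc(Cc2ccc(NC3=NCCN3)cc2)cc1` gives 8.8, and compound 2 `CC(C)Oc1ccc(Cc2ccc(NC3=NCCN3)cc2)cc1` gives 8.8. The next compound, compound 4 `c1cc(NC2=NCCN2)ccc1Cc1ccc(OC2CCCC2)cc1`, keeps the shared core but carries a different group: cyclopentyl in place of 2-hydroxyethyl on an oxygen on an aromatic ring. In words, cyclopentyl takes the place of 2-hydroxyethyl on an oxygen on an aromatic ring.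

Among the compounds with values here, three measured steps bear on this change. Isopropyl in place of propyl gave no change at the digits printed from compound 1 to compound 2 (within the scatter), so these two carbon-only groups show no difference. The two steps to the hydroxy-bearing chain are a number 0.80 log units lower from compound 1 to compound 3 (beyond the scatter) and a number 0.80 log units lower from compound 2 to compound 3 (beyond the scatter). Compound 4 gives up that chain for another carbon-only group, so these two steps are expected to run roughly in reverse. Within the data shown here, no cyclopentyl compound has been measured yet, so the effect of the ring itself remains unknown. The expected change is a number 0.70 log units higher from compound 3 to compound 4 (beyond the scatter). Compound 4 is estimated at 8.7, with an expected range from 8.2 to 9.2.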

Compound 4, negative logarithm of the antagonist equilibrium constant: 8.9
The estimate for compound 4 lay 0.20 log units below the measured number, within the range that was stated.
By their numbers in this assay, from the lowest: compound 3; then compounds 1, 2 and 4 (each within the scatter of the next).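

In this assay, cyclopentyl in place of 2-hydroxyethyl on the oxygen gives a number 0.90 log units higher from compound 3 to compound 4 (beyond the scatter), so a carbon-only ring serves here as well as the carbon-only chains do. Compared with those chains, the ring shows a number 0.10 log units higher from compound 2 to compound 4 (within the scatter) and a number 0.10 log units higher from compound 1 to compound 4 (within the scatter), which means that among compound 1, compound 2 and compound 4, going from an open chain to a five-membered ring makes no visible difference at this position. Nothing shown here gives a reason for these numbers.

As far as these compounds go, whether the position would take a six-membered ring such as cyclohexyl, or a much longer chain such as octyl, remains open. From the compounds shown here alone, it also remains open how a 2-methoxyethyl or 2-aminoethyl group would compare with the 2-hydroxyethyl group of compound 3.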